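Hydrogen in Place of Ethyl on an Aromatic Ring Oxygen

The source may report more compounds than this note shows. Statements on the series, on what has been measured and on what is new or still open speak of the compounds shown alone.

Going by the values given here, compound 2 `CCOc1ccc(CN2CCC(C(=O)Nc3cc(Cl)c(N)cc3OC)CC2)cc1` is the one compound here with a number: in a functional assay on the whole organism for antagonist activity, with Mus musculus as the target (a lower number here means that less compound is needed, a higher number that more compound is needed for the effect), compound 2 gives 6.3 mg/kg. Compound 1 `COc1cc(N)c(Cl)cc1NC(=O)C1CCN(Cc2ccccc2Cl)CC1` reaches only a limit of this assay, > 4 mg/kg. Among the compounds with values here, the step that the limit leaves unreadable from compound 1 to compound 2 therefore cannot be read, so no measured step bears on the change to compound 3 `COc1cc(N)c(Cl)cc1NC(=O)C1CCN(Cc2ccc(O)cc2)CC1`, which is hydrogen in place of ethyl on an oxygen on an aromatic ring. With no measured guide, a step of no change at the digits printed from compound 2 to compound 3 (within the scatter) no larger than the usual scatter is expected. Compound 3 is estimated at 6.3 mg/kg in this assay, between 2.5 mg/kg and 16 mg/kg.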

Compound 3, dose for half-maximal effect: > 8 mg/kg
Compound 3 was reported as a limit; the forecaster's own chance of this, stated with the estimate: 25%; middle value at least 1.2-fold (0.10 log units) from the limit.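

Putting hydrogen in place of ethyl on the ring oxygen, which turns 4-ethoxyphenyl into 4-hydroxyphenyl, gives in this assay an at least 1.2-fold higher number from compound 2 to compound 3 (0.10 log units; that floor lies within the scatter). Going by these compounds alone, this is the only step here with any readable direction, and it offers no sign that the free hydroxy lowers the dose needed. Compound 3 reaches only a limit, > 8 mg/kg, so this step has a floor but no measured size.

The steps from compound 1 cannot be read. A methoxy or a longer chain such as propoxy on this oxygen could show how the number follows the size of the group there.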